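Trading benzyl for isopropyl on an aromatic oxygen

A few compounds are considered here, and "the series" means these few. Any claim that something is new, unique, unknown or untested is made for them only; others in the source may bear on it.

Going by the values given here, in a functional assay on thoracic aorta (Rattus norvegicus, strain Wistar), with a stated time of 15 min (on this read-out higher numbers stand for an effect only at larger amounts of compound and lower numbers for an effect already at smaller amounts), compound 2 (`CC(NC(=O)NS(=O)(=O)c1ccccc1)c1cc(Br)ccc1OCc1ccccc1`) gives 130000 nM, the highest of the two numbers measured so far. Compound 1 (`CC(C)Oc1ccc(Br)cc1C(C)NC(=O)N(C)S(=O)(=O)c1ccccc1`) gives 32100 nM, a lower number, and the gap between them lies beyond the usual scatter. Compound 3 (`CC(C)Oc1ccc(Br)cc1C(C)NC(=O)NS(=O)(=O)c1ccccc1`) comes from compound 2 by placing isopropyl in place of benzyl on an oxygen on an aromatic ring. Among the compounds with values here, no measured pair shows this change alone, so the expectation rests on thin evidence. Compound 1 carries isopropoxy as compound 3 does, though the two are not identical, and compound 1 at 32100 nM points towards a lower number. In this assay the expected step is a 2.9-fold lower number from compound 2 to compound 3 (0.46 log units; beyond the scatter), a drop estimated to lie modestly beyond the scatter. For compound 3 the estimated value is 45000 nM, with an expected range from 15000 nM to 130000 nM.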

Compound 3, half-maximal effective concentration: 143000 nM
The estimate for compound 3 lay 3.2-fold (0.50 log units) below the measured number, outside the stated range (above it).
By their numbers in this assay, from the lowest: compound 1; then compounds 2 and 3 (each within the scatter of the next).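

On an oxygen on an aromatic ring, isopropyl in place of benzyl makes no readable difference in this assay: the step is a 1.1-fold higher number from compound 2 to compound 3 (0.04 log units; within the scatter), so this site tolerates the exchange of benzyloxy for isopropoxy without a shift beyond the scatter. The earlier numbers had suggested otherwise, but the second step separates the two changes: with hydrogen in place of methyl on an amide-type nitrogen there is a 4.5-fold higher number from compound 1 to compound 3 (0.65 log units; beyond the scatter), so the lower number of compound 1 goes with that methyl, a modest effect seen in this single pair. Nothing available explains either result.

As far as these compounds go, whether ethyl or a longer chain on that nitrogen would carry the shift further remains open. So does the outcome of a chain bearing an amine on the aromatic oxygen.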